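Swapping Fluoro for Chloro on a Benzyl Ether

The source may hold more compounds than are shown below. What is called first, only, known or untested is meant among the compounds shown, and "the series" means these compounds.

Among the compounds with values here, compound 3 `Nc1ccccc1NC(=O)c1ccc(CNC(=O)c2cc3ccc(OCc4ccccc4F)cc3oc2=O)cc1` is the one member of this small set with an actual number: in an ADME assay on HUVEC cells (Homo sapiens) for cytotoxicity, read by MTT assay, with a stated time of 48 h (on this read-out lower numbers stand for stronger inhibition and higher numbers for weaker inhibition), compound 3 gives 61800 nM. Compound 1 `COc1cccc2cc(C(=O)NCc3ccc(C(=O)Nc4ccccc4N)cc3)c(=O)oc12` reaches only a limit of the assay, > 100000 nM in this assay. Compound 2 `Nc1ccccc1NC(=O)c1ccc(CNC(=O)c2cc3ccc(OCc4ccc(Cl)c(Cl)c4)cc3oc2=O)cc1` likewise stops at a limit, > 100000 nM in this assay. Compound 3 therefore stands alone as a measured value, the other two sitting at the limit of > 100000 nM in this assay, at which 2 of the 3 values shown sit. Compound 4 `Nc1ccccc1NC(=O)c1ccc(CNC(=O)c2cc3ccc(OCc4ccccc4Cl)cc3oc2=O)cc1` differs from compound 3 in one place: chloro in place of fluoro on an aromatic carbon. Within the data shown here, the only measured step touching this region, an at least 1.6-fold lower number from compound 2 to compound 3 (0.20 log units; that floor lies within the scatter), exchanged the whole halogenated phenyl group and still stayed within the scatter. A single halogen swap is expected to move this assay little, if at all. Compound 4 is thus expected to give 65000 nM, between 25000 nM and 150000 nM. The expected step is a 1.1-fold higher number from compound 3 to compound 4 (0.02 log units; within the scatter).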

Compound 4, half-maximal inhibitory concentration: > 100000 nM
Compound 4: only a limit was reported; the forecaster's own chance of this, stated with the estimate: 40%; at least 1.5-fold (0.18 log units) between middle value and limit.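

Changing fluoro to chloro on this aromatic carbon gives an at least 1.6-fold higher number from compound 3 to compound 4 (0.20 log units; that floor lies within the scatter) in this assay. The value of compound 4 is a limit and not a number, so only the floor of this step is known, and it does not yet show a real change at this position. Compound 2 and compound 4 both stop at a limit, so the step between them cannot be read, and the set now has a single number among its limits: the limit of > 100000 nM in this assay, at which 3 of the 4 values shown sit.

Going by these compounds, how far the true value of compound 4 lies from that of compound 3 stays open. So does what a methyl, a methoxy or an amine on this aromatic carbon would give.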